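Ortho substituent swap on the phenylpiperazine of compound 3

The source may report more compounds than this note shows. Statements on the series, on what has been measured and on what is new or still open speak of the compounds shown alone.

Compound 1 `COc1ccccc1N1CCN(CCCNc2ncccc2C(=O)N(C)C)CC1` gives 20 nM in a functional assay on aorta for antagonist activity at Alpha-1D adrenergic receptor (Rattus norvegicus); on this read-out higher numbers stand for weaker binding and lower numbers for tighter binding.
Compound 2 `CN(C)C(=O)c1cccnc1NCCCN1CCN(c2ccccc2C#N)CC1` gives 10 nM in this assay.
Compound 3 `CN(C)C(=O)c1cccnc1NCCCN1CCN(c2ccccc2-c2ncco2)CC1` gives 25.1 nM in this assay.

Compound 3 carries the highest of the three numbers; its nearest neighbour is compound 1, a change of a 1.3-fold higher number from compound 1 to compound 3 (0.10 log units; within the scatter), and its furthest is compound 2, a change of a 2.5-fold higher number from compound 2 to compound 3 (0.40 log units; beyond the scatter). Compound 4 `Cc1ccccc1N1CCN(CCCNc2ncccc2C(=O)N(C)C)CC1` differs from compound 3 by methyl in place of 1,3-oxazol-2-yl on an aromatic carbon. Going by the values given here, no measured step exchanges the 1,3-oxazol-2-yl for a methyl, so the three measured groups in this position only bracket the outcome: all three numbers lie close together, with compound 2 alone set beyond the scatter. Compound 4 is therefore expected to give a number near that of compound 1, a step of a 1.4-fold lower number from compound 3 to compound 4 (0.14 log units; within the scatter) from compound 3, estimated at 18 nM with a range from 7 nM to 45 nM.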

Compound 4, dissociation constant: 10 nM
Compound 4: the middle estimate sits 1.8-fold (0.26 log units) above what was measured, and the stated range covers the measured number.
By their numbers in this assay, from the lowest: compounds 2, 4, 1 and 3 (each within the scatter of the next, the first and the last beyond it).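

Methyl in place of 1,3-oxazol-2-yl gives a step beyond the scatter in this assay (a 2.5-fold lower number from compound 3 to compound 4 (0.40 log units; beyond the scatter)), so the 1,3-oxazol-2-yl now stands apart from both cyano and methyl at this place, though not from methoxy. Methyl and cyano cannot be told apart (no change at the digits printed from compound 2 to compound 4 (within the scatter)), and methyl and methoxy also lie within the scatter (a 2.0-fold lower number from compound 1 to compound 4 (0.30 log units; within the scatter)).

No measurement given here explains the gap between methyl and 1,3-oxazol-2-yl. Going by these compounds, whether a chlorine atom or an amine at this place would group with methyl or with 1,3-oxazol-2-yl remains open.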